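A few compounds are considered here, and "the series" means these few. Any claim that something is new, unique, unknown or untested is made for them only; others in the source may bear on it.

The measured compounds, with their numbers in a functional assay on OVCAR-5 cells (Homo sapiens) for inhibition, read by sulforhodamine B assay, with a stated time of 48 h, tested at 0.01 uM; a higher number here means a weaker effect of the compound at the concentration tested, a lower number a stronger effect:

Compound 1, `COc1cc(Cl)cc(-c2nn(-c3cccc(NC(=O)Nc4ccc(Cl)c(C(F)(F)F)c4)c3)cc2-c2ccncc2)c1`, gives 54%.
Compound 2, `COc1cc(Cl)cc(-c2nn(-c3cccc(NC(=O)Nc4cc(C(F)(F)F)cc(C(F)(F)F)c4)c3)cc2-c2ccncc2)c1`, gives 99%.
Compound 3, `COc1cc(Cl)cc(-c2nn(-c3cccc(NC(=O)Nc4ccc(Cl)c(Cl)c4)c3)cc2-c2ccncc2)c1`, gives 93%.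

Compound 3 stands second highest of the three numbers in this assay. Its nearest neighbour is compound 2, whose number lies within the scatter of that of compound 3, so the two cannot be ordered. Compound 1 lies furthest away: a number 39 percentage points higher from compound 1 to compound 3 (beyond the scatter), a large step.

The next compound, compound 4, `COc1cc(Cl)cc(-c2nn(-c3cccc(NC(=O)Nc4cccc(C(F)(F)F)c4)c3)cc2-c2ccncc2)c1`, has not yet been measured in this assay. It differs from compound 3 in one place: 3-(trifluoromethyl)phenyl in place of 3,4-dichlorophenyl on an amide-type nitrogen. Among the compounds with values here, only one measured step bears on this change, the one from compound 1 to compound 3, in which a trifluoromethyl became a chloro and the number rose by a large amount. Within the data shown here, compound 4 carries a trifluoromethyl again, which points back toward a lower number, but it also lacks a chloro that compound 1 and compound 3 both carry, and no measured pair shows what that costs. The expectation is therefore a step downward from compound 3, of uncertain size: a number 15 percentage points lower from compound 3 to compound 4 (beyond the scatter). Compound 4 is estimated at 78%, with a range from 52% to 100%.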

Compound 4, a percentage reported as activity, at one concentration (the size of the read-out at that concentration, not a potency): 94%
The estimate for compound 4 lay 16 percentage points below the measured number; measured number inside the range.
By their numbers in this assay, from the lowest: compound 1; then compounds 3, 4 and 2 (each within the scatter of the next).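

In this assay, the trifluoromethyl group alone does not carry the stronger effect seen with compound 1: the step that removes the chloro and leaves 3-(trifluoromethyl)phenyl on the amide-type nitrogen is a number 40 percentage points higher from compound 1 to compound 4 (beyond the scatter), a large one. The other two changes at this place leave no readable difference, with a number 1 percentage points higher from compound 3 to compound 4 (within the scatter) when 3,4-dichlorophenyl gives way to 3-(trifluoromethyl)phenyl, and a number 5 percentage points lower from compound 2 to compound 4 (within the scatter) when a hydrogen replaces the second trifluoromethyl, so that compounds 2, 3 and 4 form one group and, among the four, only the chloro and trifluoromethyl pairing of compound 1 stands apart. Nothing available here accounts for why that pairing differs from the rest.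

The compounds shown leave open whether a phenyl carrying a single chloro, with no trifluoromethyl, would behave like compound 1 or like compound 4, and whether a methyl, a nitrile or a dimethylamino group could take the place of that chloro. Each number is also a reading at one concentration, so it shows only how strong or weak the effect of each compound is at that concentration and nothing about other concentrations.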